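Cytotoxicity Outlook for a Hydroxylated Analogue of Compound 1

A few compounds are considered here, and "the series" means these few. Any claim that something is new, unique, unknown or untested is made for them only; others in the source may bear on it.

Measured so far:
compound 1 `CC[C@@H](Nc1nc(SC)nc2c1ccn2[C@H]1[C@H](O)[C@H](O)[C@]2(CO)C[C@H]12)C1CC1`, with > 50000 nM
compound 2 `NC(=O)c1ncn([C@H]2[C@H](O)[C@H](O)[C@]3(CO)C[C@H]23)n1`, with > 50000 nM

In an ADME assay on Vero 76 cells (Chlorocebus sabaeus) for cytotoxicity, read by neutral red uptake (on this read-out higher numbers stand for lower toxicity in this test and lower numbers for higher toxicity in this test), compound 1 gives > 50000 nM, which is a limit of the assay and not a number. Compound 2 likewise gives > 50000 nM in this assay, again only a limit. Compound 1 therefore stands at the limit of > 50000 nM in this assay, at which 2 of the 2 values shown sit, so nothing in the numbers sets it apart from compound 2.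

Compound 3 `CSc1nc(N[C@@H](C2CC2)C(C)(C)O)c2ccn([C@H]3[C@H](O)[C@H](O)[C@]4(CO)C[C@H]34)c2n1` has not yet been measured in this assay. It differs from compound 1 in one place: 1-hydroxy-1-methylethyl in place of ethyl on a saturated chain carbon bound to a nitrogen on an aromatic ring and a saturated ring carbon.

Among the compounds with values here, no step between two measured compounds is available, so no measured change can be pointed to. Since both shown values sit at the limit, the step from compound 1 to compound 3 is expected to be a number no higher from compound 1 to compound 3 (the limit leaves the size open), none beyond the scatter. Compound 3 is estimated at 50000 nM, expected to fall between 25000 nM and 100000 nM.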

Compound 3, half-maximal cytotoxic concentration: > 100000 nM
Compound 3 was reported as a limit; the forecaster's own chance of this, stated with the estimate: 85%; middle value at least 2.0-fold (0.30 log units) away from the limit.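

In this assay compound 1 gives > 50000 nM, a limit and not a number. Within the data shown here, compound 3 gives > 100000 nM, again a limit, so no step from compound 1 to compound 3 can be read. From the compounds shown here alone, the true cytotoxic concentration of each compound stays open, as does whether swapping ethyl for 1-hydroxy-1-methylethyl changes it.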